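Cyano substitution on the core of compound 1

The source may report more compounds than this note shows. Statements on the series, on what has been measured and on what is new or still open speak of the compounds shown alone.

Measured compounds:
- compound 1 `C=C(Cl)C(=O)Nc1cc(Nc2nccc(-c3cn(C)c4ccccc34)n2)c(OC)cc1N(C)CCN(C)C`: 7520 nM
- compound 2 `C/C=C\C(=O)Nc1cc(Nc2nccc(-c3cn(C)c4ccccc34)n2)c(OC)cc1N(C)CCN(C)C`: 660 nM

In a functional assay on A549 cells (Homo sapiens) for antiproliferative activity, read by MTT assay, with a stated time of 72 h (a higher number here means a weaker inhibitor, a lower number a stronger inhibitor), compound 1 gives 7520 nM, the higher of the two numbers. Compound 2 gives 660 nM, and the step of an 11-fold lower number from compound 1 to compound 2 (1.06 log units; beyond the scatter) concerns the group on the carbonyl carbon only. Compound 3 `C=C(Cl)C(=O)Nc1cc(Nc2ncc(C#N)c(-c3cn(C)c4ccccc34)n2)c(OC)cc1N(C)CCN(C)C` differs from compound 1 elsewhere: cyano in place of hydrogen on an aromatic carbon. Among the compounds with values here, no measured step touches this position, so the change has nothing to lean on. A step of no more than the scatter is therefore expected, a 1.3-fold lower number from compound 1 to compound 3 (0.10 log units; within the scatter). For compound 3 the estimate in this assay is 6000 nM, within 2000 nM to 20000 nM.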

Compound 3, half-maximal inhibitory concentration: 133 nM
Compound 3: the middle estimate sits 45-fold (1.65 log units) above what was measured; measured number below the stated range.
By their numbers in this assay, from the lowest: compound 3; then compound 2; then compound 1.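

Until now only the group on the carbonyl carbon had been seen to move the number. In this assay, the step of a 57-fold lower number from compound 1 to compound 3 (1.75 log units; beyond the scatter) shows that the core position ortho to a 1-methyl-1H-indol-3-yl group also matters, and that cyano there is a large gain over hydrogen. Nothing measured here bears on the reason for this step.

As far as these compounds go, it remains open whether cyano brings a similar gain with prop-1-en-1-yl on the carbonyl carbon. From the compounds shown here alone, it is also open whether a methyl group, a chlorine atom or a carboxylic acid at this position would match cyano.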